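A few compounds are considered here, and "the series" means these few. Any claim that something is new, unique, unknown or untested is made for them only; others in the source may bear on it.

Compound 2 `c1ccc(C(c2ccccc2)N2CCN(c3ncnc4c3cnn4-c3ccccc3)CC2)cc1` carries a phenyl on a saturated chain carbon bound to an amine nitrogen in a ring and an aromatic carbon. In a functional assay on cells (Rhabdomyosarcoma cell, Homo sapiens) for cytotoxicity (on this read-out lower numbers stand for stronger inhibition and higher numbers for weaker inhibition), compound 2 gives only a limit of the assay, > 25000 nM. Compound 1 `c1ccc(C(c2ccco2)N2CCN(c3ncnc4c3cnn4-c3ccccc3)CC2)cc1`, which bears a furan-2-yl at that same place, likewise returns a limit in this assay, > 25000 nM. The step that the two limits leave unreadable from compound 1 to compound 2 is therefore not readable in size, and both compounds rest at the same limit (the limit of > 25000 nM in this assay, at which 2 of the 2 values shown sit). Compound 3 `c1ccc(C(c2nccs2)N2CCN(c3ncnc4c3cnn4-c3ccccc3)CC2)cc1` differs from compound 2 by 1,3-thiazol-2-yl in place of phenyl on a saturated chain carbon bound to an amine nitrogen in a ring and an aromatic carbon. Within the data shown here, the only measured step that touches this place, a step that the two limits leave unreadable from compound 1 to compound 2, has no readable size, so it gives no direction for an exchange of the aromatic group at that carbon. With two compounds at the limit and no readable step, compound 3 is expected to show no change beyond the scatter in this assay, and its value is expected most likely to sit at the limit again, a step that the limit leaves unreadable from compound 2 to compound 3. Compound 3 is expected to give about 40000 nM, in the range 12000 nM to 150000 nM.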

Compound 3, half-maximal inhibitory concentration: > 25000 nM
Compound 3: only a limit was reported; the forecaster's own chance of this, stated with the estimate: 80%; the middle value is on the limit's open side.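

Among these compounds, compound 3 also gives only a limit in this assay, > 25000 nM, so no step among compound 1, compound 2 and compound 3 can be read, and all three rest at the same limit: the limit of > 25000 nM in this assay, at which 3 of the 3 values shown sit. The compounds shown leave open whether the furan-2-yl, phenyl and 1,3-thiazol-2-yl groups differ in this assay.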